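Working notes: dichloroquinolinyl exchange and cell toxicity

A few compounds are considered here, and "the series" means these few. Any claim that something is new, unique, unknown or untested is made for them only; others in the source may bear on it.

Compound 1 `C=C1CC[C@@H]2[C@](C)(CO)[C@H](O)CC[C@@]2(C)[C@@H]1C/C=C1/C(=O)OC[C@@H]1Oc1cccc2ccc(C)nc12` and compound 2 `C=C1CC[C@@H]2[C@](C)(CO)[C@H](O)CC[C@@]2(C)[C@@H]1C/C=C1/C(=O)OC[C@@H]1Oc1c(Cl)cc(Cl)c2cccnc12` share one core; compound 3 `C=C1CC[C@H]2[C@@](C)(CCC(=O)[C@@]2(C)COC(C)=O)[C@@H]1C/C=C1/C(=O)OC[C@@H]1Oc1cccc2ccc(C)nc12` and the unmeasured compound 4 `C=C1CC[C@H]2[C@@](C)(CCC(=O)[C@@]2(C)COC(C)=O)[C@@H]1C/C=C1/C(=O)OC[C@@H]1Oc1c(Cl)cc(Cl)c2cccnc12` share another. The difference between the two cores is not broken down here.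

In an ADME assay on SNB-19 cells (Homo sapiens) for cytotoxicity, read by MTT assay, with a stated time of 24 h (on this read-out lower numbers stand for higher toxicity in this test and higher numbers for lower toxicity in this test), compound 1 reaches only a limit of the test, > 100000 nM. Compound 2 likewise gives only a limit in this assay, > 100000 nM. Among the compounds with values here, compound 3 is the single compound with a number in this assay, at 51700 nM.

The change from compound 1 to compound 2 is 5,7-dichloroquinolin-8-yl in place of 2-methylquinolin-8-yl on an oxygen on a saturated carbon. Its size is a step that the two limits leave unreadable from compound 1 to compound 2, which cannot be read because the limit of > 100000 nM in this assay, at which 2 of the 3 values shown sit, holds both ends of the pair.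

Compound 4 carries the same change on the core of compound 3: 5,7-dichloroquinolin-8-yl in place of 2-methylquinolin-8-yl on an oxygen on a saturated carbon. The place is worded identically in both pairs, so this is the same change, now on the second core. Within the data shown here, no measured step with a readable size exists for it, and the one earlier instance sits entirely at the limit.

Given that, the expectation for compound 4 rests on compound 3 at 51700 nM alone, and the step from compound 3 to compound 4 in this assay is expected to be small, a 1.2-fold higher number from compound 3 to compound 4 (0.06 log units; within the scatter). Compound 4 is estimated at 60000 nM in this assay, with a range from 25000 nM to 150000 nM, and a real chance that only a limit is reported.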

Compound 4, half-maximal cytotoxic concentration: 72000 nM
Compound 4: the middle estimate sits 1.2-fold (0.08 log units) below what was measured; measured number inside the range.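

In this assay, within the data shown here, 5,7-dichloroquinolin-8-yl in place of 2-methylquinolin-8-yl on an oxygen on a saturated carbon gives a 1.4-fold higher number from compound 3 to compound 4 (0.14 log units; within the scatter), the only step for this change whose size can be read. On the core of compound 3, the exchange therefore leaves the read-out within the usual scatter, and this single pair gives no sign that the change matters for cell toxicity on that core. It does not show that the change carries across cores, as the step from compound 1 to compound 2 cannot be read and no size is available to set beside the readable one, because both compounds give a limit and not a number: the limit of > 100000 nM in this assay, at which 2 of the 4 values shown sit.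

Still open, on these data alone, is whether a group of a different kind, such as an amine or a carboxylic acid in place of either quinolinyl group on an oxygen on a saturated carbon, would give a step beyond the scatter in this assay. Among these compounds, also open is how the two cores compare on their own, as compound 1 and compound 3 differ in more than one place and no step between them can be read.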